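A few compounds are considered here, and "the series" means these few. Any claim that something is new, unique, unknown or untested is made for them only; others in the source may bear on it.

Compound 1, with the structure `NS(=O)(=O)c1cccc(/N=C2\NC(=O)/C(=C3/C(=O)Nc4ccc(Cl)cc43)S2)c1`, gives the lowest of the three numbers recorded so far. In a functional assay on Caco-2 cells (Homo sapiens) for antiproliferative activity, read by MTT assay (on this read-out higher numbers stand for weaker inhibition and lower numbers for stronger inhibition), compound 1 gives 5870 nM. The nearest of the other two is compound 3, `NS(=O)(=O)c1ccc(/N=C2\NC(=O)/C(=C3/C(=O)N(Cc4ccccc4)c4ccc(Cl)cc43)S2)cc1`, which in this assay gives 13700 nM; the gap between these two numbers lies beyond the usual scatter of repeated measurements. Furthest away is compound 2, `Cc1cc(C)c2c(c1)/C(=C1/S/C(=N/c3ccc(S(N)(=O)=O)cc3)NC1=O)C(=O)N2`, which in this assay gives 146000 nM, a number far above that of compound 1 and well beyond the scatter. No pair among these three differs in only one place, so no single structural step can be read off from them directly.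

Compound 4, `COc1ccc2c(c1)/C(=C1/S/C(=N/c3cccc(S(N)(=O)=O)c3)NC1=O)C(=O)N2`, has not been measured. It differs from compound 1 in one place: methoxy in place of chloro on an aromatic carbon of the shared core. For the measured compounds named here, no measured pair shows this exchange, so the expectation rests on the three numbers above alone. Compound 4 is expected to give a somewhat higher number than compound 1, a step of a 2.0-fold higher number from compound 1 to compound 4 (0.31 log units; beyond the scatter) that is estimated to reach just past the usual scatter. For compound 4 the estimate in this assay is 12000 nM, with a range from 4000 nM to 40000 nM.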

Compound 4, half-maximal inhibitory concentration: 8390 nM
For compound 4 the middle estimate is 1.4-fold (0.16 log units) above the measured one; low and high end bracket the measured number.
By their numbers in this assay, from the lowest: compounds 1, 4 and 3 (each within the scatter of the next, the first and the last beyond it); then compound 2.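

For the compounds shown here, the exchange of methoxy in place of chloro on an aromatic carbon of the shared core provides the first single-place step, and in this assay it gives a 1.4-fold higher number from compound 1 to compound 4 (0.16 log units; within the scatter), so the two numbers cannot be separated on this read-out. At this position, meta to a fused ring and para to a fused ring, chloro with 1 heavy atom and no hydrogen-bond acceptor and methoxy with 2 heavy atoms and 1 hydrogen-bond acceptor therefore give numbers that stay within the usual scatter. No independent measurement given here bears on the reason for this result.

The compounds shown leave open how this position would respond to a group of another kind, such as an amine, a carboxylic acid or a longer chain such as butoxy, since chloro and methoxy are the only two groups compared there. They also leave open whether the same exchange would read alike on the structure of compound 3, which carries a benzyl group and so offers a different setting for the same change.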